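A few compounds are considered here, and "the series" means these few. Any claim that something is new, unique, unknown or untested is made for them only; others in the source may bear on it.

Measured so far:
Compound 1 `COc1ccc(OC)c(-c2cc(-c3ccccc3)nn2-c2ccc(S(N)(=O)=O)cc2)c1` — 31400 nM in a functional assay on cells (Cancer cell lines, Homo sapiens) for cytotoxicity, read by sulforhodamine B assay, with a stated time of 48 h; a higher number here means a weaker inhibitor of growth, a lower number a stronger inhibitor of growth
Compound 2 `Oc1ccc(O)c(-c2cc(-c3ccccc3)nn2-c2ccccc2)c1` — 26900 nM in this assay

Two compounds carry numbers, and neither stands apart: the gap between compound 2 and compound 1 is within the scatter, so the two read as alike. Compound 2 has the hydroquinone-type ring with two hydroxyls and an unsubstituted phenyl on the ring nitrogen, while compound 1 pairs two methoxy groups with a sulfamoyl on that phenyl. For the measured compounds named here, the two differ in two places at once, so no single step between them can be read off.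

Compound 3 `NS(=O)(=O)c1ccc(-n2nc(-c3ccccc3)cc2-c2cc(O)ccc2O)cc1` keeps the two hydroxyls of compound 2 and adds the sulfamoyl: sulfamoyl in place of hydrogen on an aromatic carbon. Going by the values given here, no measured pair isolates this change. Among the compounds with values here, the only guide is that compound 1, which carries the same sulfamoyl, gives 31400 nM in this assay, a number that does not separate from compound 2. On that basis the step is expected to be small, with no direction beyond the scatter, perhaps a slight move to a lower number.

For compound 3 the value in this assay is expected to be 22000 nM, within a range of 8000 nM to 60000 nM, meaning an expected step of a 1.2-fold lower number from compound 2 to compound 3 (0.09 log units; within the scatter).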

Compound 3, concentration for 50% growth inhibition: 88900 nM
Compound 3: middle estimate off by 4.0-fold (0.61 log units), on the low side; the measured number lies above the stated range.
By their numbers in this assay, from the lowest: compounds 2 and 1 (each within the scatter of the next); then compound 3.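

For the compounds shown here, this is the first read of a single change at this position: sulfamoyl in place of hydrogen on an aromatic carbon, para to a large group, gives a 3.3-fold higher number from compound 2 to compound 3 (0.52 log units; beyond the scatter) in this assay with the two hydroxyls held fixed, so here the added sulfamoyl goes with weaker growth inhibition. With the sulfamoyl held fixed, 2,5-dihydroxyphenyl in place of 2,5-dimethoxyphenyl gives a 2.8-fold higher number from compound 1 to compound 3 (0.45 log units; beyond the scatter) in this assay and also goes with weaker growth inhibition, so compound 3 combines the two features and is the weakest of the three compounds. Nothing available bears on the reason for either step.

The compounds shown leave open whether the sulfamoyl step keeps its direction and size when the 2,5-dimethoxyphenyl group replaces the 2,5-dihydroxyphenyl group, and whether the two steps simply add or depend on each other. Also open, going by these compounds, is whether an amine or a carboxylic acid in place of the sulfamoyl, at the same position on the same core, would move the number in the same direction.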